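Fluorophenyl Returns to the Amide of a Pyrazole Core

This account rests on a few compounds, and the source may have more. Where it says the series, first, only, none or still open, it means among the compounds named here.

Measured compounds:
- compound 1, `O=C(Nc1cc(-c2ccccc2)nn1-c1ccccc1)c1ccc(F)c(F)c1`, in an assay on CHO cells with metabotropic glutamate receptor 5 (Homo sapiens) as the target (on this read-out higher numbers stand for an effect only at larger amounts of compound and lower numbers for an effect already at smaller amounts), compound 1 gives 10 nM
- compound 2, `O=C(Nc1cc(-c2ccccc2)nn1-c1ccccc1)c1cnccn1`, in this assay compound 2 gives 200 nM

Among the measured compounds shown here, compound 2 stands at the highest of the two numbers so far; its nearest neighbour, compound 1, lies a 20-fold higher number from compound 1 to compound 2 (1.30 log units; beyond the scatter) below it, and that step came with the swap of pyrazin-2-yl for 3,4-difluorophenyl on the carbonyl carbon. Compound 3, `O=C(Nc1cc(-c2ccccc2)nn1-c1ccccc1)c1ccccc1F`, is not yet measured. It differs from compound 2 by 2-fluorophenyl in place of pyrazin-2-yl on a carbonyl carbon. For the measured compounds named here, one measured step bears on this change: the step of a 20-fold higher number from compound 1 to compound 2 (1.30 log units; beyond the scatter), which came from the same kind of exchange run the other way. A fluorophenyl group re-entering in place of pyrazin-2-yl is therefore expected to bring the number down by a large margin, although the 2-fluorophenyl of compound 3 is not the same group as the 3,4-difluorophenyl of compound 1. For compound 3 the estimate is 20 nM, between 5 nM and 80 nM, which would mean a step of a 10-fold lower number from compound 2 to compound 3 (1.00 log units; beyond the scatter).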

Compound 3, half-maximal effective concentration: 75 nM
Compound 3: the middle estimate sits 3.8-fold (0.57 log units) below what was measured; the measured number falls inside the stated range.
By their numbers in this assay, from the lowest: compound 1; then compound 3; then compound 2.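

In this assay, 2-fluorophenyl in place of pyrazin-2-yl on the carbonyl carbon gives a real but partial recovery (a 2.7-fold lower number from compound 2 to compound 3 (0.43 log units; beyond the scatter)), so the return of a fluorophenyl group does not by itself restore the number of compound 1. The two fluorophenyl groups also differ from each other at this place (a 7.5-fold higher number from compound 1 to compound 3 (0.88 log units; beyond the scatter)), a step beyond the scatter, which shows that the number depends on which fluorophenyl group is present and not merely on a ring of carbon only replacing pyrazin-2-yl. No measurement at hand accounts for either step.

The compounds shown leave open how plain phenyl or 4-fluorophenyl would stand at this place. They also leave open whether pyridin-2-yl would fall nearer to pyrazin-2-yl or to the fluorophenyl groups.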